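The compounds below may be only part of what the source reports. "The series", "measured", "known", "first", "only" and "open" are said of these compounds alone.

Measured in a functional assay on A549 cells (Homo sapiens) for inhibition, read by sulforhodamine B assay; on this read-out higher numbers stand for weaker inhibition of growth and lower numbers for stronger inhibition of growth:
Compound 1 `Cc1ccc2[nH]c(-c3ccc(-c4ccc(-c5cccc(Cl)c5)cc4)cc3)nc2c1`: 2800 nM
Compound 2 `COc1ccc(-c2ccc(-c3ccc(-c4nc5cc(C)ccc5[nH]4)cc3)cc2)cc1OC`: 2100 nM
Compound 3 `COc1cc(-c2ccc(-c3ccc(-c4nc5cc(C)ccc5[nH]4)cc3)cc2)cc(OC)c1OC`: < 100 nM (a limit)

Compound 3 stands at < 100 nM, which is a limit of the assay and not a number. On these data alone, its exact value is unknown.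

Compound 4 `COc1cc(-c2ccc(-c3ccc(-c4nc5ccccc5[nH]4)cc3)cc2)cc(OC)c1OC` differs from compound 3 in one place: hydrogen in place of methyl on an aromatic carbon. This is hydrogen in place of methyl on an aromatic carbon, with 5-methyl-1H-benzimidazol-2-yl becoming 1H-benzimidazol-2-yl.

Going by the values given here, no measured step touches this methyl, which all three measured compounds carry, so the evidence is indirect. The measured steps change another part of the molecule. The first is a 1.3-fold lower number from compound 1 to compound 2 (0.12 log units; within the scatter), with 3,4-dimethoxyphenyl in place of 3-chlorophenyl. The second is an at least 21-fold lower number from compound 2 to compound 3 (1.32 log units; beyond the scatter), with methoxy in place of hydrogen.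

Compound 4 keeps the methoxy of that second step, an at least 21-fold lower number from compound 2 to compound 3 (1.32 log units; beyond the scatter), so it is expected to stay close to compound 3, with no step beyond the scatter in this assay and no direction favoured. The estimated change is a step that the limit leaves unreadable from compound 3 to compound 4. The estimate for compound 4 is 70 nM, with an expected range from 15 nM to 400 nM.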

Compound 4, concentration for 50% growth inhibition: 2110 nM
Compound 4: the middle estimate sits 30-fold (1.48 log units) below what was measured, outside the stated range (above it).
By their numbers in this assay, from the lowest: compounds 2, 4 and 1 (each within the scatter of the next). At a limit, below all of these: compound 3.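

In this assay, going by these compounds alone, hydrogen in place of methyl, which turns 5-methyl-1H-benzimidazol-2-yl into 1H-benzimidazol-2-yl, gives an at least 21-fold higher number from compound 3 to compound 4 (1.32 log units; beyond the scatter), the first reading of this position, since the earlier compounds all carry the methyl. The methoxy gain seen earlier, an at least 21-fold lower number from compound 2 to compound 3 (1.32 log units; beyond the scatter), therefore depends on the methyl in these compounds: with the methyl gone and the methoxy still in place, the number is no longer low. The value of compound 3 is a limit, so this step gives only a bound and its true size stays unknown: the limit of < 100 nM in this assay, at which 1 of the 4 values shown sits.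

The compounds shown do not tell whether the methyl itself is what this carbon requires, or whether another group there, such as an ethyl group, a chlorine atom or an amine, would hold the number as low. They also leave open whether removing the methyl matters at all when the far ring is the 3,4-dimethoxyphenyl or the 3-chlorophenyl, as only the compound with the added methoxy has been compared with and without it.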